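The source may hold more compounds than are shown below. What is called first, only, known or untested is meant among the compounds shown, and "the series" means these compounds.

Measured compounds:
compound 1 `COc1cc(/C=C/C(=O)c2cccc(-n3cc(-c4ccccc4)[nH]c3=O)c2)ccc1O`, 2670 nM
compound 2 `COc1cc(/C=C/C(=O)c2cccc(-n3cc(-c4ccccc4)[nH]c3=O)c2)cc(OC)c1OC`, 1310 nM
compound 3 `COc1cc(/C=C/C(=O)c2cccc(-n3cc(-c4cc(OC)c(OC)c(OC)c4)[nH]c3=O)c2)cc(OC)c1OC`, 1800 nM

In a functional assay on Malme-3M cells (Homo sapiens) for inhibition (on this read-out higher numbers stand for weaker inhibition of growth and lower numbers for stronger inhibition of growth), compound 1 gives 2670 nM. Compound 3 gives 1800 nM, a gap that lies within the scatter, whereas compound 2 gives 1310 nM, a gap that lies beyond it, so compound 1 stands as the weaker inhibitor of that pair.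

Compound 4 `COc1cc(/C=C/C(=O)c2cccc(-n3cc(-c4ccc(Cl)cc4)[nH]c3=O)c2)ccc1O` differs from compound 1 by chloro in place of hydrogen on an aromatic carbon. Within the data shown here, the only measured step available, a 1.4-fold higher number from compound 2 to compound 3 (0.14 log units; within the scatter), altered the same phenyl group, but through three methoxy groups rather than a single chloro, and it stayed within the scatter. Among the measured compounds shown here, no measured pair shows a chloro entering in place of an aromatic hydrogen on this core, so the expectation for compound 4 rests on that one step alone. On this basis no step beyond the scatter is expected from compound 1 to compound 4 in this assay, the expected step being a 1.1-fold lower number from compound 1 to compound 4 (0.03 log units; within the scatter). Compound 4 is therefore estimated at 2500 nM, with a range from 900 nM to 7000 nM.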

Compound 4, concentration for 50% growth inhibition: 3060 nM
Compound 4: middle estimate off by 1.2-fold (0.09 log units), on the low side; the measured number falls inside the stated range.
By their numbers in this assay, from the lowest: compounds 2, 3, 1 and 4 (each within the scatter of the next, the first and the last beyond it).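

In this assay, the change from phenyl to 4-chlorophenyl gives a 1.1-fold higher number from compound 1 to compound 4 (0.06 log units; within the scatter), so a single chlorine atom placed para to a large group leaves the number within the scatter. Among these compounds, the only earlier change at this phenyl group, a 1.4-fold higher number from compound 2 to compound 3 (0.14 log units; within the scatter), also stayed within the scatter, but it involved three methoxy groups and a different group at the other end of the molecule, so two different changes on two different backgrounds now show no step beyond the scatter at this ring. Nothing measured here accounts for this result, which stands as an observation only.

As far as these compounds go, it remains open whether an amine, a carboxylic acid or a longer chain in this same place would also leave the number within the scatter, and whether chloro on another carbon of this ring would behave as it does here. Also open, from the compounds shown here alone, is whether the same chloro change would hold on the background of compound 2, which gives 1310 nM with an unsubstituted phenyl group.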